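The source may report more compounds than this note shows. Statements on the series, on what has been measured and on what is new or still open speak of the compounds shown alone.

Values in a functional assay on MCF7 cells (Homo sapiens) for antiproliferative activity, read by MTT assay; on this read-out lower numbers stand for stronger inhibition and higher numbers for weaker inhibition:
Compound 1, `NS(=O)(=O)c1ccc(/N=C2\NC(=O)/C(=C3/C(=O)Nc4ccc(Br)cc43)S2)cc1`: 11300 nM
Compound 2, `Cc1ccc2c(c1)/C(=C1/S/C(=N/c3ccc(S(N)(=O)=O)cc3)NC1=O)C(=O)N2`: > 200000 nM (a limit of the assay, not a number)
Compound 3, `COc1ccc2c(c1)/C(=C1/S/C(=N/c3ccc(S(N)(=O)=O)cc3)NC1=O)C(=O)N2`: 125000 nM

Compound 1 holds the lowest of the two numbers in this assay, with compound 3 nearest at an 11-fold higher number from compound 1 to compound 3 (1.04 log units; beyond the scatter). For compound 2 the assay reports only a limit, (the limit of > 200000 nM in this assay, at which 1 of the 3 values shown sits). Both measured steps away from compound 1 concern a substituent on an aromatic carbon: an at least 17-fold higher number from compound 1 to compound 2 (1.24 log units; beyond the scatter) and an 11-fold higher number from compound 1 to compound 3 (1.04 log units; beyond the scatter), while between compound 2 and compound 3 the step is an at least 1.6-fold lower number from compound 2 to compound 3 (0.20 log units; that floor lies within the scatter).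

Compound 4, `NS(=O)(=O)c1ccc(/N=C2\NC(=O)/C(=C3/C(=O)N(Cc4ccccc4)c4ccc(Br)cc43)S2)cc1`, differs from compound 1 in another place: benzyl in place of hydrogen on an amide-type nitrogen in a ring. Among the compounds with values here, none of the measured steps touches that amide-type nitrogen, so they give no direct guide to the size or direction of this change. In this assay compound 4 is therefore expected to lie near compound 1, with a wide range on either side. The expected step is a 1.3-fold higher number from compound 1 to compound 4 (0.12 log units; within the scatter). The estimate for compound 4 is 15000 nM, between 3000 nM and 80000 nM.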

Compound 4, half-maximal inhibitory concentration: > 200000 nM
Compound 4: no number, only a limit (the forecaster's own chance of this, stated with the estimate: 10%); middle value at least 13-fold (1.12 log units) away from the limit.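

In this assay, within the data shown here, the amide-type nitrogen proves to be a place where a single change matters, which none of the earlier compounds could show: benzyl in place of hydrogen gives an at least 17-fold higher number from compound 1 to compound 4 (1.24 log units; beyond the scatter), a large step. Compound 4 gives > 200000 nM, which is a limit of the assay and not a number. Compound 4 keeps the bromo group of compound 1 and differs from it only at this nitrogen, so this one change is enough to take the read-out to the limit: the limit of > 200000 nM in this assay, at which 2 of the 4 values shown sit.

The compounds shown carry only hydrogen and benzyl on this nitrogen, so it remains open whether any group there has this outcome or whether it belongs to benzyl, and methyl or a longer chain ending in an amine would be needed to tell these apart. Also open, on these data alone, is how far the step from compound 1 to compound 4 goes beyond its printed floor, since only that floor can be read from the limit.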